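A few compounds are considered here, and "the series" means these few. Any claim that something is new, unique, unknown or untested is made for them only; others in the source may bear on it.

Measured compounds in an ADME assay (Mus musculus) for pharmacokinetics; a lower number here means that the compound disappears faster, a higher number that the compound lasts longer:
compound 1 `CC(=O)NCn1cc(-c2ccc(C3=CCS(=O)(=O)CC3)cc2)c(=O)o1` gives 0.203 h
compound 2 `CC(=O)NCn1cc(-c2ccc(-c3ccc(C(=O)O)cc3)cc2)c(=O)o1` gives 0.142 h
compound 3 `CC(=O)NCn1cc(-c2ccc(C3=CCN(C(C)=O)CC3)cc2)c(=O)o1` gives 0.107 h

The three compounds share one core and differ only in the terminal group on the outer aryl ring. Compound 3 returns the smallest number of the three in this assay, but the gap to compound 2 and the gap to compound 1 both lie within the usual scatter of repeated measurements, so the three values cannot be told apart on the numbers in hand. Within the data shown here, no pair of measured compounds differs in a single place, so no measured step is available from which to read the effect of a small change.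

Compound 4 `CC(=O)NCn1cc(-c2ccc(C3=CCN(C(=O)CO)CC3)cc2)c(=O)o1` is not yet measured. It differs from compound 3 by hydroxy in place of hydrogen on a saturated chain carbon bound to a carbonyl carbon, read one bond further out as acetyl to (hydroxymethyl)carbonyl.

With no measured step of this kind in the set, and all three measured numbers sitting within the scatter of one another, the step of a 1.1-fold higher number from compound 3 to compound 4 (0.05 log units; within the scatter) is expected to stay within the scatter, in no particular direction. Compound 4 is therefore estimated at 0.12 h, with a range from 0.05 h to 0.3 h.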

Compound 4, half-life: 0.392 h
Beside the measured number, compound 4's estimate is 3.3-fold (0.51 log units) below it, and the stated range ends below it.
By their numbers in this assay, from the lowest: compounds 3, 2, 1 and 4 (each within the scatter of the next, the first and the last beyond it).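

Hydroxy in place of hydrogen on a saturated chain carbon bound to a carbonyl carbon gives the first readable step of the series in this assay, namely a 3.7-fold higher number from compound 3 to compound 4 (0.56 log units; beyond the scatter). The earlier compounds shown here included no pair differing in one place, and their numbers lay within the scatter of one another, so they gave no sign that any single change could move this read-out; this step shows that, with the rest of compound 3 unchanged, going from acetyl to (hydroxymethyl)carbonyl does so beyond the scatter. No measurement at hand bears on why the half-life responds to this change.

Going by these compounds, all of this rests on one pair of compounds, so it remains open whether the same change would give a step of similar size and direction on another terminal group of the shared core. Also open, on these data alone, is whether the hydroxy itself is what matters at this position, or whether a methoxy, an amine or a longer chain such as hydroxyethyl would give a similar half-life.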